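Ester to acid at the tetrazole-bearing aryl of compound 2

The source may report more compounds than this note shows. Statements on the series, on what has been measured and on what is new or still open speak of the compounds shown alone.

For the measured compounds named here, compound 2 `COC(=O)c1ccc(-c2nnn(CC(=O)C(C)Oc3ccc(Oc4ccc(C(F)(F)F)cc4)cc3)n2)cc1` gives 6.2 in a physicochemical assay for lipophilicity, read by HPLC, tested at 5 mM (on this read-out lower numbers stand for lower lipophilicity and higher numbers for higher lipophilicity), the highest of the three numbers so far. Compound 1 `COC(=O)c1ccc(-c2nnn(CC(=O)C(C)Oc3ccc(Oc4ccc(Cl)cc4)cc3)n2)cc1` gives 6.1, and compound 3 `COC(=O)c1ccc(-c2nnn(CC(=O)C(C)Oc3ccc(-c4ccccc4)cc3)n2)cc1` gives 5.4. The measured steps all sit at the far aryl: a number 0.10 log units higher from compound 1 to compound 2 (within the scatter), a number 0.70 log units lower from compound 1 to compound 3 (beyond the scatter) and a number 0.80 log units lower from compound 2 to compound 3 (beyond the scatter). Compound 4 `CC(Oc1ccc(Oc2ccc(C(F)(F)F)cc2)cc1)C(=O)Cn1nnc(-c2ccc(C(=O)O)cc2)n1` differs from compound 2 elsewhere: hydrogen in place of methyl on an oxygen next to a carbonyl group. Going by the values given here, no measured step covers this change, so the expectation is unsupported by a neighbouring pair. A clear fall in this assay is nevertheless expected, a number 2.00 log units lower from compound 2 to compound 4 (beyond the scatter). Compound 4 is estimated at 4.2, between 3.2 and 5.4.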

Compound 4, partition coefficient: 3.5
Compound 4: middle estimate off by 0.70 log units, on the high side; low and high end bracket the measured number.
By their numbers in this assay, from the lowest: compound 4; then compound 3; then compounds 1 and 2 (each within the scatter of the next).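

Hydrogen in place of methyl on an oxygen next to a carbonyl group is the first change at this end of the series that can be read in this assay, and it gives a number 2.70 log units lower from compound 2 to compound 4 (beyond the scatter). This large step exceeds the largest step at the far aryl, a number 0.80 log units lower from compound 2 to compound 3 (beyond the scatter). Nothing available here accounts for the size of this fall.

On these data alone, whether methoxycarbonyl to carboxy gives a fall of similar size on the cores of compound 1 and compound 3 remains open. Also open, as far as these compounds go, is where a primary amide or a sulfonamide in the same place would fall in this assay.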